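Swapping an Amide for a Sulfonamide in Compound 3

A few compounds are considered here, and "the series" means these few. Any claim that something is new, unique, unknown or untested is made for them only; others in the source may bear on it.

Compound 1 `O=C(/C=C/c1cccc(NC(=O)c2ccccc2Br)c1)c1nc2ccccc2[nH]1` has the lowest number of the two measured here: in a functional assay on HCT-116 cells (Homo sapiens) for antiproliferative activity, read by MTT assay, with a stated time of 48 h (a lower number here means a stronger inhibitor, a higher number a weaker inhibitor), compound 1 gives 1680 nM, while compound 2 `COc1ccc(C(=O)Nc2cccc(/C=C/C(=O)c3nc4ccccc4[nH]3)c2)cc1` gives 4880 nM, so a 2.9-fold higher number from compound 1 to compound 2 (0.46 log units; beyond the scatter). Compound 3 `O=C(/C=C/c1cccc(NS(=O)(=O)c2cccc(Cl)c2)c1)c1nc2ccccc2[nH]1` differs from compound 1 by (3-chlorophenyl)sulfonyl in place of (2-bromophenyl)carbonyl on a nitrogen on an aromatic ring. Within the data shown here, no measured step touches that linker, so the only guide is that changing the aryl group produced a modest loss in a 2.9-fold higher number from compound 1 to compound 2 (0.46 log units; beyond the scatter). A step of roughly that size toward a higher number is expected, so a 1.9-fold higher number from compound 1 to compound 3 (0.28 log units; within the scatter). Compound 3 is therefore estimated at 3200 nM, within 800 nM to 12000 nM.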

Compound 3, half-maximal inhibitory concentration: 737 nM
Beside the measured number, compound 3's estimate is 4.3-fold (0.64 log units) above it; the measured number lies below the stated range.
By their numbers in this assay, from the lowest: compound 3; then compound 1; then compound 2.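

The earlier pair changed only the aryl group on a carbonyl, whereas this change replaces the carbonyl link on the nitrogen with a sulfonyl link, and the result is a 2.3-fold lower number from compound 1 to compound 3 (0.36 log units; beyond the scatter) in this series. The gap to the methoxy analogue is wider, with a 6.6-fold lower number from compound 2 to compound 3 (0.82 log units; beyond the scatter) at the same position, so (3-chlorophenyl)sulfonyl gives the lowest number of the three groups shown. No supporting measurement explains this gain.

Going by these compounds, the link and the aryl group changed together, so their separate shares remain unknown. A (2-bromophenyl)sulfonyl or methylsulfonyl group on this nitrogen would leave that question less open.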